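The source may hold more compounds than are shown below. What is called first, only, known or untested is meant among the compounds shown, and "the series" means these compounds.

Compound 1 `CC(C)(C)OC(=O)/C=C1/C(=O)Nc2ccccc21` gives 59.6% in a functional assay on OVCAR-3 cells (Homo sapiens) for inhibition, read by CCK-8 assay, with a stated time of 72 h, tested at 20 uM; on this read-out lower numbers stand for less inhibition of growth and higher numbers for more inhibition of growth at the one concentration tested. Compound 2 `CC(C)(C)OC(=O)/C=C1/C(=O)N(Cc2ccccc2)c2ccccc21` gives 58.9% in this assay.

Compound 1 stands highest of the two numbers, though a number 0.7 percentage points lower from compound 1 to compound 2 (within the scatter) lies within the scatter, so the two compounds cannot be ordered. Compound 3 `Cc1ccc2c(c1)/C(=C\C(=O)OC(C)(C)C)C(=O)N2` is not yet measured. It differs from compound 1 by methyl in place of hydrogen on an aromatic carbon. Going by the values given here, the only measured step, from compound 1 to compound 2, concerns the ring nitrogen, not an aromatic carbon, and was small; it offers no sign of a large effect from a single added carbon on this core. Compound 3 is therefore expected to show a number 0.6 percentage points lower from compound 1 to compound 3 (within the scatter), and its estimated value is 59% with a range of 46% to 72%.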

Compound 3, percent growth inhibition at one concentration: 59.5%
Compound 3: middle estimate off by 0.5 percentage points, on the low side; low and high end bracket the measured number.
By their numbers in this assay, from the lowest: compounds 2, 3 and 1 (each within the scatter of the next).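

With methyl in place of hydrogen on an aromatic carbon, the result is a number 0.1 percentage points lower from compound 1 to compound 3 (within the scatter) in this assay. Going by these compounds alone, this is the first reading at the six-membered aromatic ring, since the earlier step concerned only the ring nitrogen, and at this carbon the read-out does not separate methyl from hydrogen. No measured evidence bears on this result.

As far as these compounds go, whether an amine, a carboxylic acid or a longer chain on this same aromatic carbon would read like methyl stays open. So does whether methyl on another carbon of that ring would read the same.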